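The compounds below may be only part of what the source reports. "The series", "measured", "known", "first", "only" and "open" are said of these compounds alone.

Compound 1 `C[C@H](Oc1ccc(S(C)(=O)=O)cc1C(=O)N1Cc2ccccc2C1)C(F)(F)F` gives 2540 nM in an assay on CHO cells for inhibition of sodium- and chloride-dependent glycine transporter 1 (Homo sapiens), read by scintillation counting (on this read-out higher numbers stand for an effect only at larger amounts of compound and lower numbers for an effect already at smaller amounts), the largest of the three numbers measured, though the gaps to both other compounds are within the scatter: compound 2 `C[C@H](Oc1ccc(S(C)(=O)=O)cc1C(=O)N1Cc2ccc(N3CCN(C)CC3)cc2C1)C(F)(F)F` gives 2080 nM, and compound 3 `COc1cccc2c1CN(C(=O)c1cc(S(C)(=O)=O)ccc1O[C@@H](C)C(F)(F)F)C2` gives 1940 nM. Compound 4 `C[C@H](Oc1ccc(S(C)(=O)=O)cc1C(=O)N1Cc2ccc(C3CCCCO3)cc2C1)C(F)(F)F` differs from compound 1 in one place: oxan-2-yl in place of hydrogen on an aromatic carbon. Within the data shown here, two measured steps bear on a substituent entering at an aromatic carbon of the shared core, a 1.2-fold lower number from compound 1 to compound 2 (0.09 log units; within the scatter) and a 1.3-fold lower number from compound 1 to compound 3 (0.12 log units; within the scatter), and neither leaves the scatter. On this basis the step of a 1.1-fold lower number from compound 1 to compound 4 (0.02 log units; within the scatter) is expected to stay within the scatter as well. The number for compound 4 in this assay is estimated at 2400 nM, with a range from 1200 nM to 4800 nM.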

Compound 4, half-maximal effective concentration: 205 nM
Compound 4: middle estimate off by 12-fold (1.07 log units), on the high side, and the stated range ends above it.
By their numbers in this assay, from the lowest: compound 4; then compounds 3, 2 and 1 (each within the scatter of the next).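

Substitution at this aromatic carbon can move the number in this assay beyond the scatter, with oxan-2-yl giving a 12-fold lower number from compound 1 to compound 4 (1.09 log units; beyond the scatter) in place of hydrogen. The entering group decides the outcome, as the same carbon shows a 10-fold lower number from compound 2 to compound 4 (1.01 log units; beyond the scatter) when oxan-2-yl replaces 4-methylpiperazin-1-yl, a group that stayed within the scatter of hydrogen. Nothing available explains this difference between the two groups.

Open, on these data alone, is whether the ring oxygen of oxan-2-yl matters, which a cyclohexyl group at this carbon would test. Also open, as far as these compounds go, is whether oxan-4-yl, attached through a different ring carbon, would serve equally.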